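Notes on compound 4: chloro to hydrogen in the series

This account rests on a few compounds, and the source may have more. Where it says the series, first, only, none or still open, it means among the compounds named here.

Measured so far:
compound 1 `CC1(C)N=C(N)N=C(N)N1c1ccc(CCC(=O)Nc2ccc(S(=O)(=O)F)cc2)c(Cl)c1` 7.62
compound 2 `CC1(C)N=C(N)N=C(N)N1c1ccc(Cl)c(OCCOc2ccc(S(=O)(=O)F)cc2)c1` 7.27
compound 3 `CN(C)C(=O)c1cccc(NC(=O)NCc2cccc(N3C(N)=NC(N)=NC3(C)C)c2)c1` 7.77

The three compounds were tested in an assay on isolated protein for inhibition of Dihydrofolate reductase (Mus musculus); a higher number here means a more potent compound, by a factor of ten per unit of this negative logarithm, a lower number a less potent compound. Compound 2 stands lowest of the three numbers. Compound 1 lies nearest to it, a number higher by a margin beyond the usual scatter, and compound 3 lies furthest, also higher by a margin beyond the scatter. Among the measured compounds shown here, the three compounds differ in several places at once, so no single step between them can be read off; only their values can be compared.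

Compound 4 `CC1(C)N=C(N)N=C(N)N1c1cccc(OCCOc2ccc(S(=O)(=O)F)cc2)c1` has not yet been measured. It is derived from compound 2 by one change: hydrogen in place of chloro on an aromatic carbon The group leaves an aromatic carbon of a six-membered aromatic ring of carbon only, ortho to a large group and para to a large group, and a hydrogen atom takes its place.

For the measured compounds named here, no measured pair shows this exact change, so the expected size of the step rests on the general weight of a chloro group. A modest loss is expected, beyond the scatter but not large: the estimated step is a number 0.37 log units lower from compound 2 to compound 4 (beyond the scatter). For compound 4 the estimate in this assay is 6.9, with a range from 6.4 to 7.4.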

Compound 4, logarithm of the reciprocal of the active concentration, log(1/C): 7.82
The estimate for compound 4 lay 0.92 log units below the measured number; the whole stated range lies below it.
By their numbers in this assay, from the lowest: compound 2; then compounds 1, 3 and 4 (each within the scatter of the next).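

In this assay, hydrogen in place of chloro on this aromatic carbon, ortho to a large group and para to a large group, gives a number 0.55 log units higher from compound 2 to compound 4 (beyond the scatter), so in this compound the chloro is not required for potency and its removal brings a modest gain. Among the compounds shown here, the earlier compounds differed in several places at once and could not isolate any one position; this pair gives the series its only single-place step, and it holds for this one setting alone. Nothing measured here bears on why the step runs in this direction.

Going by these compounds, it remains open whether a fluoro, methyl or methoxy group on the same carbon would give a value closer to that of compound 2 or to that of compound 4, which would show whether the step tracks the chloro specifically or any group larger than hydrogen. On these data alone, compound 1 also carries a chloro, on a different chain and linker, and whether hydrogen in its place would give a step of similar size and direction also remains open.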